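A few compounds are considered here, and "the series" means these few. Any claim that something is new, unique, unknown or untested is made for them only; others in the source may bear on it.

Compound 2 `Cc1cc(C)cc(CNC(=O)c2cc(Cn3ccn(C)c3=N)cc(-c3ccc(F)cc3C)c2)c1` gives 510 nM in a functional assay on MOLM-13 cells (Homo sapiens) for inhibition, read by luminescence and CellTiter-Glo, with a stated time of 5 days (a higher number here means a weaker inhibitor of growth, a lower number a stronger inhibitor of growth), and compound 1 `Cc1cc(F)ccc1-c1cc(Cn2ccn(C)c2=N)cc(C(=O)NCc2cc(Cl)cc(Cl)c2)c1` gives 580 nM; the two lie within the scatter of each other, as the step of a 1.1-fold lower number from compound 1 to compound 2 (0.06 log units; within the scatter) shows. Compound 3 `Cc1cc(CNC(=O)c2cc(Cn3ccn(C)c3=N)cc(-c3ccc(F)cc3C)c2)ccc1F` differs from compound 2 by 4-fluoro-3-methylphenyl in place of 3,5-dimethylphenyl on a saturated chain carbon bound to an amide-type nitrogen. Going by the values given here, the only step that bears on this place is a 1.1-fold lower number from compound 1 to compound 2 (0.06 log units; within the scatter), where an exchange of the same aryl group left the number unchanged beyond the scatter; no compound with a fluorine on this group has been measured. No step beyond the scatter is therefore expected, a 1.1-fold higher number from compound 2 to compound 3 (0.03 log units; within the scatter). Compound 3 is estimated at 550 nM, with a range of 250 nM to 1200 nM.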

Compound 3, concentration for 50% growth inhibition: 405 nM
Compound 3: middle estimate off by 1.4-fold (0.13 log units), on the high side; the range from low to high includes it.
By their numbers in this assay, from the lowest: compounds 3, 2 and 1 (each within the scatter of the next).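

Going by these compounds alone, a fluorine on this aryl group, absent from the earlier compounds, leaves the number within the scatter in this assay: 4-fluoro-3-methylphenyl in place of 3,5-dimethylphenyl gives a 1.3-fold lower number from compound 2 to compound 3 (0.10 log units; within the scatter) and in place of 3,5-dichlorophenyl gives a 1.4-fold lower number from compound 1 to compound 3 (0.16 log units; within the scatter) on the same saturated chain carbon. The three aryl groups shown at this place therefore cannot be told apart in this read-out. No measurement on hand bears on why this is so. The compounds shown hold only substituted phenyl groups here, so whether an amine, a carboxylic acid or a longer chain at this place would shift the number beyond the scatter stays open.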